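This account rests on a few compounds, and the source may have more. Where it says the series, first, only, none or still open, it means among the compounds named here.

Compound 2 `COc1ccc2c(=O)c(-c3cc(OC)c(OC)cc3OC)coc2c1` is the smallest member of the set. In a functional assay on HUVEC cells (Homo sapiens) for antiproliferative activity, read by MTT assay, with a stated time of 24 h (a higher number here means a weaker inhibitor, a lower number a stronger inhibitor), compound 2 returns only the assay limit of > 10000 nM, a limit and not a number (the limit of > 10000 nM in this assay, at which 1 of the 3 values shown sits). Compound 1 `COc1cc(OC)c(-c2coc3cc(OCc4ccccc4)ccc3c2=O)cc1OC` gives 9750 nM in this assay. Compound 3 `COc1cc(OC)c(-c2coc3cc(OCc4ccccc4C)ccc3c2=O)cc1OC` gives 4830 nM. The step of an at least 1.0-fold higher number from compound 1 to compound 2 (0.01 log units; that floor lies within the scatter) is bounded by that limit, whereas the step of an at least 2.0-fold lower number from compound 2 to compound 3 (0.31 log units; beyond the scatter). Compound 4 `COc1cc(OC)c(-c2coc3cc(OCc4ccc([N+](=O)[O-])cc4)ccc3c2=O)cc1OC` differs from compound 2 by 4-nitrophenyl in place of hydrogen on a saturated chain carbon bound to an oxygen on an aromatic ring. Both measured steps that place a group on the saturated chain carbon bound to an oxygen on an aromatic ring bear on it: phenyl brought a number near the limit, 2-methylphenyl a modestly lower one. For compound 4 the expected step is an at least 1.4-fold lower number from compound 2 to compound 4 (0.15 log units; that floor lies within the scatter), downward from the limit. For compound 4 the estimate is 7000 nM, with a range from 2500 nM to 20000 nM.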

Compound 4, half-maximal inhibitory concentration: > 10000 nM
Compound 4: only a limit was reported; the forecaster's own chance of this, stated with the estimate: 25%; at least 1.4-fold (0.15 log units) between middle value and limit.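

In this assay compound 4 returns only a limit, > 10000 nM. With 4-nitrophenyl in place of 2-methylphenyl on the saturated chain carbon bound to an oxygen on an aromatic ring, the series shows an at least 2.0-fold higher number from compound 3 to compound 4 (0.31 log units; beyond the scatter), so the lower number of compound 3 does not extend to compound 4, while the added nitro group gives only an at least 1.0-fold higher number from compound 1 to compound 4 (0.01 log units; that floor lies within the scatter). The step from compound 2 to compound 4 cannot be read, since both values are limits: the limit of > 10000 nM in this assay, at which 2 of the 4 values shown sit.

As far as these compounds go, whether 4-methylphenyl or 4-aminophenyl on the same carbon would behave like 2-methylphenyl or like 4-nitrophenyl stays open, so the place of the substituent and its identity cannot be separated. From the compounds shown here alone, how far compound 4 lies past its limit also stays open.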